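The compounds below may be only part of what the source reports. "The series", "measured", "known", "first", "only" and "open" are said of these compounds alone.

Compound 1 `COc1ccc(/C=N/NC(=O)c2cc(-c3ccccc3)nn2Cc2ccc(Cl)nc2)cc1` is the lower of the two compounds measured in a functional assay on A549 cells (Homo sapiens) for cytotoxicity, read by MTT assay, with a stated time of 48 h (a lower number here means a less soluble compound, a higher number a more soluble compound), where compound 1 gives 15000 nM. Going by the values given here, its only neighbour, compound 2 `O=C(N/N=C/c1ccco1)c1cc(-c2ccccc2)nn1Cc1ccc(Cl)nc1`, gives 50000 nM in this assay, and the step of a 3.3-fold higher number from compound 1 to compound 2 (0.52 log units; beyond the scatter) arises from furan-2-yl in place of 4-methoxyphenyl on a carbon with a double bond to nitrogen. Compound 3 `COc1ccc(/C=N/NC(=O)c2cc(-c3ccc(Cl)cc3)nn2Cc2ccc(Cl)nc2)cc1` differs from compound 1 elsewhere: chloro in place of hydrogen on an aromatic carbon, on an aromatic carbon of a six-membered aromatic ring of carbon only, para to a large group; read one bond further out, phenyl becomes 4-chlorophenyl. Among the compounds with values here, no measured step touches this position, so no change beyond the scatter is expected, no change at the digits printed from compound 1 to compound 3 (within the scatter). Compound 3 is therefore estimated at 15000 nM, within 6000 nM to 40000 nM.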

Compound 3, solubility: 3300 nM
Beside the measured number, compound 3's estimate is 4.5-fold (0.66 log units) above it; the measured number lies below the stated range.
By their numbers in this assay, from the lowest: compound 3; then compound 1; then compound 2.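

The phenyl group of the shared core is not a silent position: in this assay, chloro in place of hydrogen on an aromatic carbon, para to a large group, gives a 4.5-fold lower number from compound 1 to compound 3 (0.66 log units; beyond the scatter). This single added atom moves the number downward, the opposite direction to the earlier step at the other end of the molecule, a 3.3-fold higher number from compound 1 to compound 2 (0.52 log units; beyond the scatter). Nothing shown gives a reason for this step. Open, as far as these compounds go, is whether fluoro, methoxy or an amine at this carbon would move the number likewise, and whether chloro does the same when furan-2-yl replaces 4-methoxyphenyl.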